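Ester size and growth inhibition in a cinnamyl series

A few compounds are considered here, and "the series" means these few. Any claim that something is new, unique, unknown or untested is made for them only; others in the source may bear on it.

Measured compounds:
compound 1, `C=CS(=O)(=O)NC/C=C/c1cc(OC)cc(O)c1C(=O)OC(C)C`: 72.3%
compound 2, `C=CS(=O)(=O)NC/C=C/c1cc(OC)cc(O)c1C(=O)OCC1CCCCC1`: 56.4%
compound 3, `COc1cc(O)c(C(=O)OC(C)C)c(/C=C/CN2C(=O)C=CC2=O)c1`: 99.8%

All three values come from a functional assay on MV4-11 cells (Homo sapiens) for inhibition, read by luminescence, with a stated time of 72 h, tested at 5 uM; a higher number here means more inhibition of growth at the concentration tested, a lower number less inhibition of growth. Compound 2 differs from compound 1 by cyclohexylmethyl in place of isopropyl on an oxygen next to a carbonyl group; the step is a number 15.9 percentage points lower from compound 1 to compound 2 (beyond the scatter). Compound 3 differs from compound 1 by a group of 7 heavy atoms (4 carbon, 1 nitrogen, 2 oxygen; one five-membered non-aromatic ring with 1 hetero atom) in place of a group of 6 heavy atoms (2 carbon, 1 nitrogen, 2 oxygen, 1 sulfur; no ring), on a saturated chain carbon bound to a double-bonded chain carbon; the step is a number 27.5 percentage points higher from compound 1 to compound 3 (beyond the scatter), and compound 3 stands highest of the three, beyond the scatter from both others.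

Compound 4, `COc1cc(O)c(C(=O)OCC2CCCCC2)c(/C=C/CN2C(=O)C=CC2=O)c1`, is not yet measured. It differs from compound 3 by cyclohexylmethyl in place of isopropyl on an oxygen next to a carbonyl group, the same change that was made from compound 1 to compound 2, at the same place. The step is therefore expected to point the same way, but it is estimated smaller than the earlier one, a number 9.8 percentage points lower from compound 3 to compound 4 (within the scatter), because compound 3 already gives 99.8% and little room remains at the top of the scale. Compound 4 is expected to give about 90% in this assay, estimated between 72% and 100%.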

Compound 4, percent growth inhibition at one concentration: 99.8%
Estimate against measurement, compound 4: 9.8 percentage points below; the measured number falls inside the stated range.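

In this assay, the exchange of isopropyl for cyclohexylmethyl does not carry over from one core to the other at the same size, with no change at the digits printed from compound 3 to compound 4 (within the scatter) set against the earlier drop: the same change on two cores in this assay, a number 15.9 percentage points lower (beyond the scatter) from compound 1 to compound 2 and no change at the digits printed (within the scatter) from compound 3 to compound 4, 15.9 percentage points apart, beyond the scatter of two such steps. The exchange of the group on the saturated chain carbon, a number 43.4 percentage points higher from compound 2 to compound 4 (beyond the scatter), likewise differs between the two esters: the same change on two cores in this assay, a number 27.5 percentage points higher (beyond the scatter) from compound 1 to compound 3 and a number 43.4 percentage points higher (beyond the scatter) from compound 2 to compound 4, 15.9 percentage points apart, beyond the scatter of two such steps. Compound 3 gives 99.8% and compound 4 gives 99.8%, both at the top of the scale, so this single-concentration read-out cannot show whether the ester exchange has any effect on that core.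

Still open, from the compounds shown here alone, is whether the two esters separate at lower concentrations. Also open, going by these compounds, is how a carboxylic acid in place of the ester, or an ester carrying an amine, would read.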